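This account rests on a few compounds, and the source may have more. Where it says the series, first, only, none or still open, it means among the compounds named here.

Measured compounds in this set:

Compound 1 `O=C(Nc1ccc(OC(F)(F)F)cc1)NC1CCN(C(=O)C2CCOCC2)CC1` gives 91 ug/mL
Compound 2 `O=C(CC1CCN(C(=O)C2CC2)CC1)Nc1ccc(OC(F)(F)F)c(F)c1` gives 715 ug/mL
Compound 3 `O=C(Nc1ccc(OC(F)(F)F)c(F)c1)NC1CCN(C(=O)C2CCOCC2)CC1` gives 77 ug/mL

In a physicochemical assay for solubility, read by mass spectrometry, in phosphate buffer, with a stated time of 24 h, at pH 7.4 (on this read-out lower numbers stand for lower solubility and higher numbers for higher solubility), compound 1 stands second highest of the three numbers. Within the data shown here, its nearest neighbour is compound 3, and the only single-change step measured here is a 1.2-fold lower number from compound 1 to compound 3 (0.07 log units; within the scatter), a change that left the read-out within the scatter. Compound 2 sits furthest away with 715 ug/mL, but it differs from compound 1 in more than one place, so the two values show only that a larger gap exists, not what produced it.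

The unmeasured compound 4 `O=C(Nc1ccc(OC(F)(F)F)cc1)NC1CCN(C(=O)C2CCCOC2)CC1` differs from compound 1 in one place: oxan-3-yl in place of oxan-4-yl on a carbonyl carbon. Among the measured compounds shown here, no measured step in this set bears on that change; the one step that exists concerns a fluoro on an aromatic carbon, not the ring on the carbonyl carbon. With the same atoms joined differently and nothing measured to argue for a shift, the step expected in this assay is a 1.0-fold lower number from compound 1 to compound 4 (0.00 log units; within the scatter), none beyond the scatter. Compound 4 is therefore estimated at 90 ug/mL, with an expected range from 40 ug/mL to 200 ug/mL.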

Compound 4, solubility: 94 ug/mL
The estimate for compound 4 lay 1.0-fold (0.02 log units) below the measured number; low and high end bracket the measured number.
By their numbers in this assay, from the lowest: compounds 3, 1 and 4 (each within the scatter of the next); then compound 2.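

In this assay, among these compounds, oxan-3-yl in place of oxan-4-yl on a carbonyl carbon gives a 1.0-fold higher number from compound 1 to compound 4 (0.01 log units; within the scatter) and so provides the first measured step at this position, since the earlier step concerned only a fluoro on an aromatic carbon. At this position, the read-out does not separate oxan-3-yl from oxan-4-yl, two groups with the same atoms and the same counts of hydrogen-bond donors and acceptors. No supporting measurement bears on this result.

On these data alone, it remains open whether a piperidin-4-yl ring, a carboxylic acid or a longer chain on this carbonyl carbon would also stay within the scatter of compound 1. As far as these compounds go, it is also open whether oxan-3-yl would give a similar step from compound 3, with its aromatic fluoro.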